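Headgroup changes on the shared core: compound 3 to compound 4

This account rests on a few compounds, and the source may have more. Where it says the series, first, only, none or still open, it means among the compounds named here.

Measured compounds in a functional assay on MC-38 cells (Mus musculus) for antiproliferative activity, read by CCK-8 assay, with a stated time of 48 h; on this read-out lower numbers stand for stronger inhibition and higher numbers for weaker inhibition:
Compound 1, `COc1ccc(/C=C\c2cc(OC)c(OC)c(OC)c2)cc1OCc1ccc(CN2CC[C@@H](O)C2)cc1`, gives 6900 nM.
Compound 2, `COc1ccc(/C=C\c2cc(OC)c(OC)c(OC)c2)cc1OCc1ccc(CN2CC[C@H](O)C2)cc1`, gives 7200 nM.
Compound 3, `COc1ccc(/C=C\c2cc(OC)c(OC)c(OC)c2)cc1OCc1ccc(CN2CCCCC2C(=O)NCCN)cc1`, gives only a limit of the assay, > 10000 nM.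

Compound 1 and compound 2 differ only in configuration as drawn, and the step of a 1.0-fold higher number from compound 1 to compound 2 (0.02 log units; within the scatter) is consistent with the fact that compounds 1 and 2 differ only in the configuration as drawn. Compound 3 stands at the floor of the numbers shown: its value is a limit, so its position relative to the others is known only as a floor, with an at least 1.4-fold higher number from compound 1 to compound 3 (0.16 log units; that floor lies within the scatter) and an at least 1.3-fold higher number from compound 2 to compound 3 (0.14 log units; that floor lies within the scatter).

The next compound, compound 4, `COc1ccc(/C=C\c2cc(OC)c(OC)c(OC)c2)cc1OCc1ccc(CN[C@H](C(=O)O)[C@@H](C)O)cc1`, carries the change ((1-carboxy-2-hydroxypropyl)amino in place of 2-((2-aminoethyl)carbamoyl)piperidin-1-yl on a saturated chain carbon bound to an aromatic carbon). Going by the values given here, the only measured steps touching this position are those from compound 1 and compound 2 to compound 3, and both are floors within the scatter, so they give no direction for the new headgroup. The step that the limit leaves unreadable from compound 3 to compound 4 is therefore expected to be small and uncertain, with a real chance that compound 4 again reports only a limit. Compound 4 is estimated at 15000 nM, within 4000 nM to 60000 nM.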

Compound 4, half-maximal inhibitory concentration: > 10000 nM
Compound 4: only a limit was reported; the forecaster's own chance of this, stated with the estimate: 60%; the middle value lies beyond the limit too.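

In this assay compound 4 gives > 10000 nM, which is a limit of the assay and not a number. The floors against the two 3-hydroxypyrrolidin-1-yl compounds are an at least 1.3-fold higher number from compound 2 to compound 4 (0.14 log units; that floor lies within the scatter) and an at least 1.4-fold higher number from compound 1 to compound 4 (0.16 log units; that floor lies within the scatter), so the open-chain (1-carboxy-2-hydroxypropyl)amino group, which has no ring, is not shown to separate from them. The step linking compound 3 and compound 4 cannot be read, and a second, quite different headgroup on the saturated chain carbon bound to an aromatic carbon now sits at the same limit: the limit of > 10000 nM in this assay, at which 2 of the 4 values shown sit.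

On these data alone, only compound 1 and compound 2 give numbers at this place, so the size of any real loss stays open. Also open, as far as these compounds go, is whether a small tertiary amine such as dimethylamino or morpholin-4-yl, or the methyl ester of the carboxylic acid in compound 4, would give a number in this assay.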